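The compounds below may be only part of what the source reports. "The series", "measured", "known", "first", "only" and "open" are said of these compounds alone.

Measured compounds:
compound 1, `Cc1cccc(CSc2cc(Cl)c(C)cc2S(=O)(=O)/N=C(\N)n2nccc2-c2ccccc2)c1`, 6500 nM
compound 2, `Cc1cccc(CSc2cc(Cl)c(C)cc2S(=O)(=O)/N=C(\N)n2nc(C)cc2-c2ccccc2)c1`, 34000 nM
compound 3, `Cc1cc(S(=O)(=O)/N=C(\N)n2nccc2-c2ccccc2)c(SCc2ccccc2C(F)(F)F)cc1Cl`, 16000 nM

These three compounds were tested in a functional assay on HCT-116 cells (Homo sapiens) for cytotoxicity, read by MTT assay, with a stated time of 72 h; on this read-out lower numbers stand for stronger inhibition and higher numbers for weaker inhibition. Compound 1 gives 6500 nM, compound 2 gives 34000 nM and compound 3 gives 16000 nM.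

Compound 2 differs from compound 1 in one place: methyl in place of hydrogen on an aromatic carbon. This change made a step of a 5.2-fold higher number from compound 1 to compound 2 (0.72 log units; beyond the scatter). Compound 3 differs from compound 1 in the group attached to the sulfur: 2-(trifluoromethyl)phenyl in place of 3-methylphenyl on a saturated chain carbon bound to a sulfur, which gave a step of a 2.5-fold higher number from compound 1 to compound 3 (0.39 log units; beyond the scatter).

Compound 4, `Cc1cc(-c2ccccc2)n(/C(N)=N/S(=O)(=O)c2cc(C)c(Cl)cc2SCc2ccccc2C(F)(F)F)n1`, has not yet been measured in this assay. It stands to compound 3 as compound 2 stands to compound 1: methyl in place of hydrogen on an aromatic carbon. The place is the same in both pairs, so this is the same change made on the core of compound 3.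

Because the step of a 5.2-fold higher number from compound 1 to compound 2 (0.72 log units; beyond the scatter) was clearly beyond the usual scatter, a step of similar direction and size is expected here, giving an estimated 4.1-fold higher number from compound 3 to compound 4 (0.61 log units; beyond the scatter). The estimate for compound 4 in this assay is 65000 nM, expected to fall between 25000 nM and 160000 nM.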

Compound 4, half-maximal inhibitory concentration: 25000 nM
Estimate against measurement, compound 4: 2.6-fold (0.41 log units) above, within the range that was stated.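

Adding the methyl to the five-membered aromatic ring gave a 1.6-fold higher number from compound 3 to compound 4 (0.19 log units; within the scatter), so the step seen on the core of compound 1 did not carry over at its full size: the same change on two cores in this assay, a 5.2-fold higher number (0.72 log units; beyond the scatter) from compound 1 to compound 2 and a 1.6-fold higher number (0.19 log units; within the scatter) from compound 3 to compound 4, 3.3-fold (0.52 log units) apart, beyond the scatter of two such steps. Swapping 3-methylphenyl for 2-(trifluoromethyl)phenyl gave a 1.4-fold lower number from compound 2 to compound 4 (0.13 log units; within the scatter), so this change also did not behave the same way on both cores: the same change on two cores in this assay, a 2.5-fold higher number (0.39 log units; beyond the scatter) from compound 1 to compound 3 and a 1.4-fold lower number (0.13 log units; within the scatter) from compound 2 to compound 4, 3.3-fold (0.52 log units) apart, beyond the scatter of two such steps. Among these compounds, neither change can therefore be treated as a fixed step that transfers from one core to another, although four compounds in this assay show only that the two changes do not simply add up, not why.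

The compounds shown leave open whether another group on the same ring carbon, such as an ethyl, a chlorine or an amine, would also depend on the core. They also leave open how the two cores would respond if a methoxy or a nitrile took the place of the trifluoromethyl.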